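The source may report more compounds than this note shows. Statements on the series, on what has been measured and on what is new or still open speak of the compounds shown alone.

Three ureas have been measured in an ADME assay on the whole organism with Oryza sativa as the target, tested at 1 uM; on this read-out lower numbers stand for a stronger effect and higher numbers for a weaker effect at the one concentration tested. Compound 1, with the structure `CCc1ccc(NC(=O)N[C@@H](C)c2ccccc2)cc1`, gives 95%. Compound 2, with the structure `CCCc1ccc(NC(=O)N[C@@H](C)c2ccccc2)cc1`, differs from compound 1 by methyl in place of hydrogen on a saturated chain carbon, two bonds along the chain from an aromatic carbon; in this assay compound 2 gives 76%, so that the step is a number 19 percentage points lower from compound 1 to compound 2 (beyond the scatter). Compound 3, with the structure `CCCCCc1ccc(NC(=O)N[C@H](C)c2ccccc2)cc1`, gives 101%, which is within the scatter of compound 1 and beyond the scatter above compound 2. The difference between the core of compound 3 and the core of compound 1 is not broken down here.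

Compound 4, with the structure `CCCCCCc1ccc(NC(=O)N[C@H](C)c2ccccc2)cc1`, has not yet been measured. It differs from compound 3 by methyl in place of hydrogen on a saturated chain carbon, five bonds along the chain from an aromatic carbon. Among the compounds with values here, this is the same kind of change as the one from compound 1 to compound 2, but not the same: there the methyl entered two bonds along the chain from an aromatic carbon, here it enters five bonds along the chain from an aromatic carbon. With only one measured step of this kind in hand, the expectation for compound 4 rests on compound 3 giving 101% and on the step of a number 19 percentage points lower from compound 1 to compound 2 (beyond the scatter), and the author expects a step of a number 11 percentage points lower from compound 3 to compound 4 (beyond the scatter), smaller than the earlier one, since the change sits further out along the chain. In this assay compound 4 is thus estimated at 90%, with a range from 70% to 105%.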

Compound 4, a percentage reported as activity, at one concentration (the size of the read-out at that concentration, not a potency): 101%
For compound 4 the middle estimate is 11 percentage points below the measured one; the range from low to high includes it.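

In this assay, the methyl added on a saturated chain carbon, five bonds along the chain from an aromatic carbon, gives no change at the digits printed from compound 3 to compound 4 (within the scatter). Set beside the earlier step, this shows that the change of hydrogen to methyl on the chain does not carry over at one size from one core to the other in this series: the same change on two cores in this assay, a number 19 percentage points lower (beyond the scatter) from compound 1 to compound 2 and no change at the digits printed (within the scatter) from compound 3 to compound 4, 19 percentage points apart, beyond the scatter of two such steps This does not show that the core alone sets the size of the step, since the two steps also differ in place, two bonds along the chain in one and five bonds along it in the other, and the data do not separate the two; with a single pair on each core, they also give no rule for any other chain in the series.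

What the compounds shown leave open is whether the same step made at one place on both cores would match, and so whether place or core accounts for the gap. Also open, as far as these compounds go, is how this assay would respond to a longer chain, or to an amine or a carboxylic acid in place of the methyl.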